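The source may report more compounds than this note shows. Statements on the series, on what has been measured and on what is new or still open speak of the compounds shown alone.

Measured so far in a functional assay on MKN-74 cells (Homo sapiens) for antiproliferative activity, with a stated time of 24 h; on this read-out lower numbers stand for stronger inhibition and higher numbers for weaker inhibition: compound 1 `NC(=O)c1c(NC(=O)c2ccccc2F)sc2c1CCN(Cc1ccc(Cl)cc1Cl)C2` gives 9610 nM; compound 2 `NC(=O)c1c(NC(=O)c2ccccc2Cl)sc2c1CCN(C(=S)Nc1ccccc1F)C2` gives 12600 nM; compound 3 `NC(=O)c1c(NC(=O)c2ccccc2Cl)sc2c1CCN(C(=S)Nc1ccccc1C(F)(F)F)C2` gives 1870 nM.

Compound 3 has the lowest number of the three, and both gaps to it lie beyond the scatter: compound 1 sits a good deal higher, compound 2 higher still. Among the measured compounds shown here, the single one-place step known within the set runs a 6.7-fold lower number from compound 2 to compound 3 (0.83 log units; beyond the scatter); it concerns the identity of the substituent on the thiourea-bound ring, not its position.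

Compound 4 `NC(=O)c1c(NC(=O)c2ccccc2Cl)sc2c1CCN(C(=S)Nc1ccc(C(F)(F)F)cc1)C2` differs from compound 3 by 4-(trifluoromethyl)phenyl in place of 2-(trifluoromethyl)phenyl on an amide-type nitrogen. For the measured compounds named here, no measured pair moves a group from one ring position to another, so the step from compound 2 to compound 3 bears on this change only indirectly: it shows that the ring substituent matters in this assay, but says nothing about where it sits. Going by the values given here, with no positional step to lean on, the expectation for compound 4 is a change of uncertain direction and probably not beyond the scatter, which is what a 1.3-fold higher number from compound 3 to compound 4 (0.13 log units; within the scatter) reflects.

Compound 4 is therefore estimated at 2500 nM in this assay, with a range from 900 nM to 7000 nM.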

Compound 4, half-maximal inhibitory concentration: 7090 nM
For compound 4 the middle estimate is 2.8-fold (0.45 log units) below the measured one, outside the stated range (above it).
By their numbers in this assay, from the lowest: compound 3; then compounds 4, 1 and 2 (each within the scatter of the next).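

In this assay the swap of 2-(trifluoromethyl)phenyl for 4-(trifluoromethyl)phenyl on the amide-type nitrogen gives a 3.8-fold higher number from compound 3 to compound 4 (0.58 log units; beyond the scatter) and so shows that, with the same atoms joined differently, the arrangement of the group alone registers on this read-out, which the earlier substituent step could not show. The trifluoromethyl group as such therefore does not carry the lower number of compound 3: 4-(trifluoromethyl)phenyl in place of 2-fluorophenyl gives a 1.8-fold lower number from compound 2 to compound 4 (0.25 log units; within the scatter) and does not separate the two compounds. Nothing available explains this dependence on arrangement.

Still open is whether the same dependence holds for other groups on this phenyl ring, such as a methoxy group, a nitrile or a carboxylic acid, as the compounds shown compare only trifluoromethyl in both arrangements. Also open, as far as these compounds go, is whether the step persists when a carbonyl replaces the thiocarbonyl on the amide-type nitrogen.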